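Aryl Swap on the Ring Nitrogen of Compound 1

The source may report more compounds than this note shows. Statements on the series, on what has been measured and on what is new or still open speak of the compounds shown alone.

Two hydroxamic acids were measured in an assay on Sf9 cells for inhibition of protein deacetylase HDAC6 (Homo sapiens), read by fluorescence, with a stated time of 40 min, tested at 100 nM; on this read-out lower numbers stand for less inhibition and higher numbers for more inhibition at the one concentration tested (going by the name of the read-out). Compound 1 `CCc1ccc(-n2nc(-c3ccccc3)nc2CNc2ccc(C(=O)NO)cc2)cc1` gives 38.3%, the lower of the two numbers; compound 2 `O=C(NO)c1ccc(NCc2nc(-c3ccc(Br)cc3)nn2-c2ccccc2)cc1` gives 54.7%, a figure beyond the usual scatter above it. Within the data shown here, compounds 1 and 2 differ in more than one place, so no single step joins them. Compound 3 `Cc1cccc(-n2nc(-c3ccccc3)nc2CNc2ccc(C(=O)NO)cc2)c1` differs from compound 1 in one place: 3-methylphenyl in place of 4-ethylphenyl on an aromatic nitrogen. Among the measured compounds shown here, with no step between measured compounds to lean on, one expects this change to leave the read-out within the usual scatter, giving an expected step of a number 2.3 percentage points lower from compound 1 to compound 3 (within the scatter) of no clear direction. Compound 3 is therefore estimated at 36%, with a range from 15% to 58%.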

Compound 3, a percentage reported as inhibition, at one concentration (the size of the read-out at that concentration, not a potency): 66%
Compound 3: the middle estimate sits 30 percentage points below what was measured, and the stated range ends below it.
By their numbers in this assay, from the lowest: compound 1; then compound 2; then compound 3.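

Putting 3-methylphenyl in place of 4-ethylphenyl on the aromatic nitrogen gives a number 27.7 percentage points higher from compound 1 to compound 3 (beyond the scatter) in this assay. This position therefore responds to a change in its aryl group, even one this small. Nothing on hand accounts for the step.

The change alters both the carbon substituent and its place on the phenyl ring, and the compounds shown do not separate these two effects. On these data alone, it also remains open how the read-out would respond to a methoxy group or an amine in place of the methyl of 3-methylphenyl.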